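The source may report more compounds than this note shows. Statements on the series, on what has been measured and on what is new or still open speak of the compounds shown alone.

Among the compounds with values here, in an ADME assay on microsomes from liver (Mus musculus) for metabolic stability, read by LC-MS, with a stated time of 10 min (on this read-out higher numbers stand for a more stable compound and lower numbers for a less stable compound), three compounds have numbers so far: compound 1 `CC(C)N1CCN(c2cccc3c2C[C@H](CN(C)[C@H]2CCCc4cccnc42)NC3)CC1` gives 15.1%, compound 2 `CN(C[C@H]1Cc2c(cccc2N2CCN3CCC[C@H]3C2)CN1)[C@H]1CCCc2cccnc21` gives 40.1% and compound 3 `FC1(F)CCC(CN(C[C@H]2Cc3c(cccc3N3CCNCC3)CN2)[C@H]2CCCc3cccnc32)CC1` gives 76.6%. Compound 3 stands highest of the three, beyond the scatter from both of the others. Compound 4 `c1cnc2c(c1)CCC[C@@H]2N(CC1CCCCC1)C[C@H]1Cc2c(cccc2N2CCNCC2)CN1` departs from compound 3 in one place: cyclohexyl in place of 4,4-difluorocyclohexyl on a saturated chain carbon bound to an amine nitrogen, with cyclohexyl in place of 4,4-difluorocyclohexyl on a saturated chain carbon bound to an amine nitrogen. Within the data shown here, no measured step makes this change. The only one available, a number 25 percentage points higher from compound 1 to compound 2 (beyond the scatter), concerns a different group on an aromatic carbon, so it serves only as a gauge of size, showing that one change can move this assay beyond the scatter. Since compound 3 already reads 76.6%, there is more room below it than above it. The expected step is a number 21.6 percentage points lower from compound 3 to compound 4 (beyond the scatter), an estimate of similar modest size, downward. For compound 4 the estimated value is 55%, with an expected range from 32% to 75%.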

Compound 4, percent of the compound remaining: 85.6%
For compound 4 the middle estimate is 30.6 percentage points below the measured one; the whole stated range lies below it.
By their numbers in this assay, from the lowest: compound 1; then compound 2; then compounds 3 and 4 (each within the scatter of the next).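

Taking 4,4-difluorocyclohexyl out for cyclohexyl on a saturated chain carbon bound to an amine nitrogen gives a number 9 percentage points higher from compound 3 to compound 4 (within the scatter) in this assay and is the first step shown at this position, as the only earlier step concerned a group on an aromatic carbon. The two fluorine atoms are therefore not required for compound 4 to read in the same range as compound 3, and the cyclohexylmethyl form keeps the reading well clear of compound 1 and compound 2, although those two also differ elsewhere. No measurement shown here accounts for this result.

The compounds shown leave open how far this position tolerates other groups, such as a tetrahydropyran ring, a phenyl ring or a short open alkyl chain in place of cyclohexyl. They also leave open whether a methyl group on the free piperazine nitrogen would hold the reading with cyclohexylmethyl in place.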